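Cytotoxicity of Three Ureas and a Fourth Yet Unmeasured

A few compounds are considered here, and "the series" means these few. Any claim that something is new, unique, unknown or untested is made for them only; others in the source may bear on it.

Compound 1 `Cc1cc(NC(=O)Nc2ncccc2C)c2ccccc2n1`, compound 2 `Cc1cc(NC(=O)Nc2ccc(N)cc2)c2ccccc2n1` and compound 3 `Cc1cc(NC(=O)Nc2ccccc2F)c2ccccc2n1` share one core and differ only in the group on one urea nitrogen. In an ADME assay on BJ cells (Homo sapiens) for cytotoxicity, with a stated time of 72 h (a lower number here means that less compound is needed, a higher number that more compound is needed for the effect), compound 1 gives > 25000 nM, which is a limit of the assay rather than a number. Compound 2 gives > 25000 nM, also a limit. Compound 3 gives > 25000 nM, likewise a limit. Thus (the limit of > 25000 nM in this assay, at which 3 of the 3 values shown sit), and the steps a step that the two limits leave unreadable from compound 1 to compound 2, a step that the two limits leave unreadable from compound 1 to compound 3 and a step that the two limits leave unreadable from compound 2 to compound 3 cannot be sized. Compound 4 `Cc1cc(NC(=O)Nc2ccc(SC(F)(F)F)cc2)c2ccccc2n1` arises from compound 2 by (trifluoromethyl)sulfanyl in place of amino on an aromatic carbon. Among the compounds with values here, no measured step bears readably on this change, so no shift beyond the scatter can be foreseen. Compound 4 is therefore expected at 25000 nM, between 8000 nM and 60000 nM in this assay. That estimated step is a number no higher from compound 2 to compound 4 (the limit leaves the size open).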

Compound 4, half-maximal effective concentration: > 25000 nM
Compound 4: no number, only a limit; the forecaster's own chance of this, stated with the estimate: 70%; the middle value lies on the limit itself.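

Compound 2 and compound 4 both stand at a limit of the assay rather than at a number, so the step between them cannot be read: the limit of > 25000 nM in this assay, at which 4 of the 4 values shown sit. The compounds shown leave open whether changing these groups alters cytotoxicity at all.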